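One Group Swap, Made Twice Across Two Cores

This account rests on a few compounds, and the source may have more. Where it says the series, first, only, none or still open, it means among the compounds named here.

Three compounds have been measured in a functional assay on HL-60 cells (Homo sapiens) for inhibition, read by trypan blue exclusion, with a stated time of 72 h; a lower number here means a stronger inhibitor of growth, a higher number a weaker inhibitor of growth:

compound 1, `C=C(CC)C(=O)c1ccc(OCc2nc(-c3ccc4ccccc4c3)cs2)c(C)c1C`, gives 2000 nM
compound 2, `C=C(CC)C(=O)c1ccc(OCc2nc(-c3ccc(C(F)(F)F)cc3)cs2)c(C)c1C`, gives 1500 nM
compound 3, `C=C(CC)C(=O)c1ccc(OCc2nc(-c3ccc4ccccc4c3)cs2)cc1Cl`, gives 900 nM

Compound 1 and compound 2 share one core and differ only in 4-(trifluoromethyl)phenyl in place of naphthalen-2-yl on an aromatic carbon. That swap made a 1.3-fold lower number from compound 1 to compound 2 (0.12 log units; within the scatter), so the two numbers cannot be told apart with confidence.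

Compound 3 carries a different core; how it differs from compound 1 is not broken down here. Among the three it has the lowest number, but its gap to compound 2 lies within the scatter, so only its gap to compound 1 counts as a real difference.

Compound 4, `C=C(CC)C(=O)c1ccc(OCc2nc(-c3ccc(C(F)(F)F)cc3)cs2)cc1Cl`, has not yet been measured. It stands to compound 3 exactly as compound 2 stands to compound 1: the change is 4-(trifluoromethyl)phenyl in place of naphthalen-2-yl on an aromatic carbon, placed on the same kind of ring atom in both pairs, so it is the same change seen again on the second core.

Among the measured compounds shown here, the step from compound 3 to compound 4 in this assay is expected to be small, a 1.3-fold lower number from compound 3 to compound 4 (0.11 log units; within the scatter), because the only precedent, a 1.3-fold lower number from compound 1 to compound 2 (0.12 log units; within the scatter), stayed within the scatter. Going by these compounds, whether the second core responds in the same way is unknown, which widens the range. Compound 4 is estimated at 700 nM, with a likely span from 350 nM to 1400 nM.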

Compound 4, concentration for 50% growth inhibition: 2000 nM
Estimate against measurement, compound 4: 2.9-fold (0.46 log units) below; the whole stated range lies below it.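

In this assay, putting 4-(trifluoromethyl)phenyl in place of naphthalen-2-yl gave a 2.2-fold higher number from compound 3 to compound 4 (0.35 log units; beyond the scatter), a step that lies beyond the scatter. This shows that the result of the change on the core of compound 1 cannot simply be carried over to the core of compound 3, since the same swap gave clearly different steps on the two cores: the same change on two cores in this assay, a 1.3-fold lower number (0.12 log units; within the scatter) from compound 1 to compound 2 and a 2.2-fold higher number (0.35 log units; beyond the scatter) from compound 3 to compound 4, 3.0-fold (0.47 log units) apart, beyond the scatter of two such steps. It does not show why the cores respond differently, and with a single pair on each core it cannot say whether either step would hold for other groups or whether the difference between the cores is general in this series.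

Going by these compounds, it remains open how other groups on that aromatic carbon of the five-membered ring, such as a plain phenyl, a 4-methoxyphenyl or an amine like morpholine, would behave on each of the two cores. On these data alone, it is also open whether a third core, for example one carrying a methoxy group where the core of compound 3 carries its chlorine, would respond to the same swap like the core of compound 1, like the core of compound 3, or like neither.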